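This account rests on a few compounds, and the source may have more. Where it says the series, first, only, none or still open, it means among the compounds named here.

Measured so far:
Compound 1 `O=C(c1nc2cc(C(F)(F)F)ccc2s1)N1CCN(c2ccncc2)CC1` gives 17.5% in an ADME assay on RAW264.7 cells (Mus musculus) for cytotoxicity, read by MTT assay, with a stated time of 72 h, tested at 50 ug/mL; on this read-out higher numbers stand for more inhibition at the one concentration tested (going by the name of the read-out) and lower numbers for less inhibition.
Compound 2 `O=C(c1nc2ccccc2s1)N1CCN(c2ccccc2)CC1` gives 67.2% in this assay.

Compound 1 stands lowest of these two numbers. Its nearest neighbour is compound 2, whose reading lies higher by a gap beyond the usual scatter. Going by the values given here, compound 2 differs from compound 1 in more than one place, so the two values show only that the pair sits far apart and not what any single change contributes.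

The step to compound 3 `CC(=O)c1ccc(N2CCN(C(=O)c3nc4cc(C(F)(F)F)ccc4s3)CC2)cc1` is a single change: 4-acetylphenyl in place of pyridin-4-yl on an amine nitrogen in a ring. Among the compounds with values here, no step between measured compounds that differ in one place is known, so the size of this change cannot be read from a neighbouring pair. Within the data shown here, the study team expects an upward step in this assay, of moderate size and not certain to exceed the scatter, because compound 2, the only other reading, gives 67.2% with a ring of carbon only on the same nitrogen. Compound 3 is therefore estimated at 35%, in the range 10% to 65%, an expected step of a number 17.5 percentage points higher from compound 1 to compound 3 (beyond the scatter).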

Compound 3, a percentage reported as inhibition, at one concentration (the size of the read-out at that concentration, not a potency): 30.6%
Beside the measured number, compound 3's estimate is 4.4 percentage points above it; the measured number falls inside the stated range.
By their numbers in this assay, from the lowest: compound 1; then compound 3; then compound 2.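

In this assay, going by these compounds alone, the group on the amine nitrogen of the six-membered non-aromatic ring proves able to shift the reading on its own: 4-acetylphenyl in place of pyridin-4-yl gives a number 13.1 percentage points higher from compound 1 to compound 3 (beyond the scatter), the only single-place change that can be read so far. The step is modest but lies beyond the scatter, and the rest of compound 1 stays the same in compound 3, so this change alone accounts for the difference between these two readings. No measured property of either group bears on the step, so the compounds shown offer no explanation for it.

This one step replaces a ring with a hetero atom by a ring of carbon only and also adds the acetyl group, so what each of these two differences contributes remains unresolved. Going by these compounds, it also remains open whether the reading would move in the same direction with a carboxylic acid or an amine in place of the acetyl group, and how much of the distance to compound 2 depends on the trifluoromethyl group.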